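The source may report more compounds than this note shows. Statements on the series, on what has been measured and on what is new or still open speak of the compounds shown alone.

Working notes on the series in an ADME assay on J774.A1 cells (Mus musculus) for inhibition, read by MTT assay, with a stated time of 72 h; a higher number here means that more compound is needed for the effect, a lower number that less compound is needed. Compound 1 `Clc1ccc(CNc2nc(NCc3ccccc3)c3ccccc3n2)cc1` gives 3200 nM. Compound 3 `CC(C)Nc1nc(Nc2ccccc2)c2ccccc2n1` gives 12000 nM, the higher of the two actual numbers, and its gap to compound 1 lies beyond the scatter. Compound 2 `CNc1nc(NC)c2ccccc2n1` stands at > 133000 nM, which is a limit of the assay and not a number.

Compound 4 `CCNc1nc(NC(C)C)nc2ccccc12` differs from compound 3 in one place, with ethyl in place of phenyl on a nitrogen on an aromatic ring. The same difference reads as anilino to ethylamino. Among the compounds with values here, no measured pair isolates this change, so the size of the step can only be judged indirectly.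

The nearest guide is compound 2, which has no ring outside the shared core and gives the limit > 133000 nM. A move to a higher number, beyond the scatter, is therefore expected in this assay. The expected change is a 4.2-fold higher number from compound 3 to compound 4 (0.62 log units; beyond the scatter). The estimate for compound 4 is 50000 nM, with an expected range of 20000 nM to 130000 nM.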

Compound 4, half-maximal effective concentration: > 30000 nM
Compound 4: a limit, no number; the forecaster's own chance of this, stated with the estimate: 30%; the middle value does not contradict the limit.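

In this assay, within the data shown here, this is the first pair that isolates a change on a nitrogen on an aromatic ring: ethyl in place of phenyl gives an at least 2.5-fold higher number from compound 3 to compound 4 (0.39 log units; beyond the scatter). The reading for compound 4 is a limit and not a number: the limit of > 30000 nM in this assay, at which 1 of the 4 values shown sits. The step therefore fixes a direction beyond the scatter for anilino to ethylamino, but gives no upper size, and it rests on this one pair.

From the compounds shown here alone, whether the ring itself matters or only the number of carbons on this nitrogen stays open, and a longer chain such as hexyl in place of ethyl would separate the two. Also open, going by these compounds, is whether a ring without aromatic character, such as cyclohexyl, would behave like phenyl at this place.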